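A few compounds are considered here, and "the series" means these few. Any claim that something is new, unique, unknown or untested is made for them only; others in the source may bear on it.

Measured compounds: compound 1 `CS(=O)(=O)Nc1ccc2oc(-c3ccccc3)nc2c1`, compound 2 `O=S(=O)(Nc1ccc2oc(-c3ccccc3)nc2c1)c1cccc(F)c1`, compound 3 `COc1ccc(S(=O)(=O)Nc2ccc3oc(-c4ccccc4)nc3c2)cc1`. Not yet measured: compound 4 `Cc1ccc(S(=O)(=O)Nc2ccc3oc(-c4ccccc4)nc3c2)cc1`.

In an ADME assay on HEK293 cells (Homo sapiens) for cytotoxicity, read by resazurin assay, with a stated time of 48 h (a higher number here means that more compound is tolerated, a lower number that less compound is tolerated), compound 1 reaches the limit of the assay, > 100000 nM; this is a limit and not a number (the limit of > 100000 nM in this assay, at which 1 of the 3 values shown sits). Compound 2 gives 68000 nM in this assay, and compound 3 gives 91000 nM. Among the two numbers, compound 3 stands highest, with compound 2 nearest: a 1.3-fold higher number from compound 2 to compound 3 (0.13 log units; within the scatter). Against the limit of compound 1 the steps read an at least 1.4-fold lower number from compound 1 to compound 2 (0.16 log units; that floor lies within the scatter) and an at least 1.0-fold lower number from compound 1 to compound 3 (0.04 log units; that floor lies within the scatter), and both floors lie within the scatter.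

The step to compound 4 is methyl in place of methoxy on an aromatic carbon. Within the data shown here, no measured step exchanges a group on the six-membered aromatic ring of carbon only; the measured steps all exchange the group on the sulfonyl sulfur, and none of them moved the number beyond the scatter. A small exchange of methyl for methoxy on that ring is therefore expected to leave compound 4 within the scatter of compound 3, so a step of a 1.1-fold lower number from compound 3 to compound 4 (0.03 log units; within the scatter) is expected. In this assay compound 4 is estimated at 85000 nM, with a range from 45000 nM to 150000 nM.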

Compound 4, half-maximal cytotoxic concentration: 75000 nM
For compound 4 the middle estimate is 1.1-fold (0.05 log units) above the measured one; measured number inside the range.
By their numbers in this assay, from the lowest: compounds 2, 4 and 3 (each within the scatter of the next). At a limit, above all of these: compound 1.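

The methoxy-to-methyl exchange, on an aromatic carbon para to a large group, is the first exchange shown on the six-membered aromatic ring of carbon only, and in this assay it gives a 1.2-fold lower number from compound 3 to compound 4 (0.08 log units; within the scatter). Replacing the 3-fluorophenyl group on the sulfonyl sulfur with 4-methylphenyl gives a 1.1-fold higher number from compound 2 to compound 4 (0.04 log units; within the scatter), so compounds 2, 3 and 4 all lie within the scatter of one another, and neither the exchange on the ring nor the exchange of the whole aryl group separates them in this set. Compound 1 stands at a limit, which is not a number, so its comparison with 4-methylphenyl on the sulfonyl sulfur reads only as a floor, an at least 1.3-fold lower number from compound 1 to compound 4 (0.12 log units; that floor lies within the scatter), and the size of any real gap cannot be read: the limit of > 100000 nM in this assay, at which 1 of the 4 values shown sits.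

From the compounds shown here alone, whether any group at this ring position can move the number beyond the scatter remains open, for instance a primary amine, a carboxylic acid or a longer alkyl chain in place of the methyl. The compounds shown also leave open whether changes to the phenyl group on the shared core would matter, as all four compounds carry it unchanged.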